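This account rests on a few compounds, and the source may have more. Where it says the series, first, only, none or still open, it means among the compounds named here.

Measured compounds:

Compound 1, `CCCS(=O)(=O)Nc1cccc2c1CCC2c1ncc[nH]1`. In a functional assay on CHO cells for agonist activity at Alpha-1D adrenergic receptor (Homo sapiens), read by FLIPR and calcium flux (a higher number here means that more compound is needed for the effect, a lower number that less compound is needed), compound 1 gives > 10000 nM, which is a limit of the assay and not a number (the limit of > 10000 nM in this assay, at which 1 of the 3 values shown sits).
Compound 2, `c1cc(-c2nccs2)c2c(c1)C(c1ncc[nH]1)CC2`. In this assay compound 2 gives 3190 nM.
Compound 3, `c1cc(-c2cn[nH]c2)c2c(c1)C(c1ncc[nH]1)CC2`. In this assay compound 3 gives 319 nM.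

Compound 3 stands lowest of the two numbers in this assay; the nearest is compound 2, with a 10-fold lower number from compound 2 to compound 3 (1.00 log units; beyond the scatter), and the third value shown for compound 1 is a limit only.

Compound 4, `CCS(=O)(=O)Nc1cccc2c1CCC2c1ncc[nH]1`, has not yet been measured. It differs from compound 3 at one place: (ethylsulfonyl)amino in place of 1H-pyrazol-4-yl on an aromatic carbon.

Going by the values given here, the step that bears on this is the one from compound 1 to compound 3, where an at least 31-fold lower number from compound 1 to compound 3 (1.49 log units; beyond the scatter). Compound 4 reverses that change in kind, with an (ethylsulfonyl)amino group in place of the 1H-pyrazol-4-yl group, and the (ethylsulfonyl)amino group differs from the (propylsulfonyl)amino group of compound 1 only in chain length. A large step upward in this assay is therefore expected, most likely back to the limit of the assay.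

Compound 4 is estimated at 15000 nM, with the expected range from 4000 nM to 60000 nM. That estimate means a 47-fold higher number from compound 3 to compound 4 (1.67 log units; beyond the scatter).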

Compound 4, half-maximal effective concentration: > 10000 nM
Compound 4: only a limit was reported (the forecaster's own chance of this, stated with the estimate: 70%); the middle value does not contradict the limit.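

In this assay compound 4 gives > 10000 nM, which is a limit of the assay and not a number, so shortening (propylsulfonyl)amino to (ethylsulfonyl)amino on this aromatic carbon gives no readable value, and the step between compound 1 and compound 4 cannot be read, since both are limits: the limit of > 10000 nM in this assay, at which 2 of the 4 values shown sit.
Putting (ethylsulfonyl)amino in place of 1H-pyrazol-4-yl gives an at least 31-fold higher number from compound 3 to compound 4 (1.49 log units; beyond the scatter), and putting it in place of 1,3-thiazol-2-yl gives an at least 3.1-fold higher number from compound 2 to compound 4 (0.49 log units; beyond the scatter). Across these four compounds, the two with a five-membered aromatic ring at this position, compound 2 and compound 3, give readable numbers, while the two with a sulfonylamino chain, compound 1 and compound 4, do not, and no compound shown goes against this.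

From the compounds shown here alone, how the ethyl and propyl chains compare remains unknown, as does whether a still shorter methylsulfonylamino group would give a readable number. Going by these compounds, it also remains open whether a plain amine or an acetylamino group on the same aromatic carbon would behave like the sulfonylamino chains or like the five-membered rings.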